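Oral Exposure in Rat: From Compound 3 to Compound 4

The source may hold more compounds than are shown below. What is called first, only, known or untested is meant among the compounds shown, and "the series" means these compounds.

Measured so far:
compound 1, `Cc1nc(N)nc(N[C@@H]2C[C@H](CO)[C@@H](O)[C@H]2O)c1-c1nc2ccccc2s1`: 1820 ng.h/mL
compound 2, `CNc1nc(C)c(-c2nc3ccccc3s2)c(N[C@@H]2C[C@H](CO)[C@@H](O)[C@H]2O)n1`: 1080 ng.h/mL
compound 3, `CCOCCNc1nc(C)c(-c2nc3ccccc3s2)c(N[C@@H]2C[C@H](CO)[C@@H](O)[C@H]2O)n1`: 1100 ng.h/mL

These three values come from an ADME assay on the whole organism (plasma) for pharmacokinetics, with Rattus norvegicus as the target, with a stated time of 6 h, at a dose of 10 mg/kg by the oral route; a lower number here means less compound in the circulation, a higher number more compound in the circulation at the dose given. Compound 3 stands second highest of the three numbers; its nearest neighbour is compound 2, with a 1.0-fold higher number from compound 2 to compound 3 (0.01 log units; within the scatter), and its furthest is compound 1, with a 1.7-fold lower number from compound 1 to compound 3 (0.22 log units; within the scatter). The third measured step, a 1.7-fold lower number from compound 1 to compound 2 (0.23 log units; within the scatter), is likewise within the scatter, so the three substituents on the nitrogen on the aromatic ring have so far left this assay essentially unmoved.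

Compound 4, `Cc1nc(NCc2ccsc2)nc(N[C@@H]2C[C@H](CO)[C@@H](O)[C@H]2O)c1-c1nc2ccccc2s1`, is not yet measured. It differs from compound 3 in one place: thiophen-3-yl in place of ethoxymethyl on a saturated chain carbon bound to a nitrogen on an aromatic ring. Among the measured compounds shown here, none of the measured steps introduces an aromatic ring at this position, so no step bears on it directly; the three that exist vary the same nitrogen and all stayed within the scatter. On that basis compound 4 is expected to give a number of the same order as compound 3, with a 1.2-fold lower number from compound 3 to compound 4 (0.09 log units; within the scatter) lying within the scatter or at most slightly below it. The estimate for compound 4 in this assay is 900 ng.h/mL, with a range from 300 ng.h/mL to 2500 ng.h/mL.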

Compound 4, area under the concentration-time curve: 96.7 ng.h/mL
For compound 4 the middle estimate is 9.3-fold (0.97 log units) above the measured one; the whole stated range lies above it.
By their numbers in this assay, from the lowest: compound 4; then compounds 2, 3 and 1 (each within the scatter of the next).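

In this assay, among the compounds shown here, the nitrogen on the aromatic ring had so far carried hydrogen, methyl and 2-ethoxyethyl with every step inside the scatter, but this position proves able to move the number a long way: an 11-fold lower number from compound 3 to compound 4 (1.06 log units; beyond the scatter) follows from thiophen-3-yl in place of ethoxymethyl on the saturated chain carbon, and this step is large. The other two comparisons are also large, with an 11-fold lower number from compound 2 to compound 4 (1.05 log units; beyond the scatter) on adding thiophen-3-yl to that carbon and a 19-fold lower number from compound 1 to compound 4 (1.27 log units; beyond the scatter) on placing (thiophen-3-yl)methyl on the nitrogen, so the earlier flatness held for the hydrogen, methyl and 2-ethoxyethyl of compounds 1, 2 and 3 and does not extend to (thiophen-3-yl)methyl. Nothing available here accounts for this fall in exposure.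

The compounds shown leave open whether the fall belongs to thiophen-3-yl in particular or to aromatic rings at this place in general, which a phenyl or a furan-3-yl on the same saturated chain carbon would test. They also leave open whether a longer chain between the nitrogen and the thiophene, or an amine or a carboxylic acid on that ring, would give a different number.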